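The compounds below may be only part of what the source reports. "The series", "measured", "known", "first", "only" and "open" are said of these compounds alone.

Measured so far in a functional assay on MDA-MB-231 cells (Homo sapiens) for antiproliferative activity, with a stated time of 48 h; a higher number here means a weaker inhibitor, a lower number a stronger inhibitor:

compound 1, `CC(=O)c1ccc(-c2ccc(N3CCCC3)nn2)cc1` — > 25000 nM, a limit of the assay, not a number
compound 2, `CCN(CC)c1ccc(-c2cccc(C(F)(F)F)c2)nn1` — > 25000 nM, a limit of the assay, not a number
compound 3, `CCN(CC)c1ccc(-c2ccc(C(C)=O)cc2)nn1` — 5000 nM

For the measured compounds named here, compound 3 thus holds the only numerical value in this assay; the other two sit at the limit of > 25000 nM in this assay, at which 2 of the 3 values shown sit. Going by the values given here, the single measured step, an at least 5.0-fold lower number from compound 1 to compound 3 (0.69 log units; beyond the scatter), is the one that separates compound 3 from a limit. Among the compounds with values here, compound 2 and compound 3 differ in more than one place, so their values show only that compound 2 rests at the limit while compound 3 does not.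

Compound 4, `CCOC(=O)c1ccc(-c2ccc(N(CC)CC)nn2)cc1`, is not yet measured in this assay. It differs from compound 3 in ethoxy in place of methyl on a carbonyl carbon: acetyl to ethoxycarbonyl on the carbonyl carbon, while the diethylamino on the shared core is kept. Within the data shown here, none of the measured steps alters this carbonyl substituent, so none of them bears on the change; the one step on record concerns the amine and was at least modest. With no guidance from the measured steps, the expected step of a 1.2-fold higher number from compound 3 to compound 4 (0.08 log units; within the scatter) is none beyond the scatter. Compound 4 is therefore estimated at 6000 nM in this assay, within 2000 nM to 25000 nM, with a real chance that only a limit is returned.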

Compound 4, half-maximal inhibitory concentration: 1500 nM
Compound 4: middle estimate off by 4.0-fold (0.60 log units), on the high side, outside the stated range (below it).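

In this assay, the carbonyl substituent proves to be a second place on the shared core where a single change moves the number beyond the scatter: a 3.3-fold lower number from compound 3 to compound 4 (0.52 log units; beyond the scatter), with the diethylamino kept. For the compounds shown here, the only earlier step concerned the amine, an at least 5.0-fold lower number from compound 1 to compound 3 (0.69 log units; beyond the scatter), so acetyl to ethoxycarbonyl gives the first reading at this position, and it shows that a compound already off the limit can still improve through a change away from the amine. The only thing on record beyond the values themselves concerns the assay limit, and nothing here ties the gain to any feature of ethoxy.

This single pair cannot separate the contribution of the ester oxygen from that of the longer group, and a carboxylic acid, an amide or a propoxy group on the same carbonyl carbon would help to tell these apart. Also open, as far as these compounds go, is whether ethoxycarbonyl gives a similar gain with pyrrolidin-1-yl in place of diethylamino, or with other aromatic substituents on the shared core.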